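The source may report more compounds than this note shows. Statements on the series, on what has been measured and on what is new or still open speak of the compounds shown alone.

Measured compounds in the series:

Compound 1 `COC(=O)c1ccc2ccc(C(=O)N(C)C)c-2cc1`: in a physicochemical assay for solubility, with a stated time of 24 h, at pH 6.8 (on this read-out lower numbers stand for lower solubility and higher numbers for higher solubility), compound 1 gives > 64 ug/mL, which is a limit of the assay.
Compound 2 `COC(=O)c1ccc2ccc(C(=O)c3ccccc3)c-2cc1`: in this assay compound 2 gives < 1 ug/mL, which is a limit of the assay.

Where compound 2 stands: its value in this assay is the limit of < 1 ug/mL in this assay, at which 1 of the 2 values shown sits, so only a ceiling is known. The other value in the series is also a limit, (the limit of > 64 ug/mL in this assay, at which 1 of the 2 values shown sits), so no number has been read for any compound here, and the series spans the full window of the assay.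

For the measured compounds named here, the single measured step, an at least 64-fold lower number from compound 1 to compound 2 (1.80 log units; beyond the scatter), is large and beyond the scatter; it is the only step that bears on the present change.

Compound 3 `COC(=O)c1ccc2c(C(=O)c3ccccc3)cc(C(=O)c3ccccc3)c-2cc1` differs from compound 2 by benzoyl in place of hydrogen on an aromatic carbon. Going by the values given here, the one precedent, an at least 64-fold lower number from compound 1 to compound 2 (1.80 log units; beyond the scatter), shows that bringing in a benzoyl carried the number from the upper limit to the lower limit. A second benzoyl is therefore not expected to raise the number; compound 2 already sits at the lower limit, so the step in this assay from compound 2 to compound 3 is expected to be flat or downward, with the assay most likely again reporting only a limit, a step that the limit leaves unreadable from compound 2 to compound 3.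

Estimate for compound 3 in this assay: 0.3 ug/mL, expected between 0.05 ug/mL and 1.5 ug/mL.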

Compound 3, solubility: < 1 ug/mL
Compound 3: only a limit was reported; the forecaster's own chance of this, stated with the estimate: 85%; the middle value does not contradict the limit.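

In this assay compound 3 gives < 1 ug/mL, which is a limit of the assay. For the compounds shown here, compound 2 gives < 1 ug/mL, also a limit, so no step from compound 2 to compound 3 can be read. The compounds shown leave open how far apart compound 2 and compound 3 lie in solubility, with both held at one reported value: the limit of < 1 ug/mL in this assay, at which 2 of the 3 values shown sit.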